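The source may report more compounds than this note shows. Statements on the series, on what has been measured and on what is new or still open speak of the compounds shown alone.

Compound 1 `COc1ccccc1C(=O)O[C@@H]1C[C@H](C)CC[C@H]1C(C)C`: 4.57
Compound 2 `CC(C)[C@@H]1CC[C@@H](C)C[C@H]1OC(=O)c1ccc(Br)cc1`: 5.61
Compound 3 `CCC(=O)O[C@@H]1C[C@H](C)CC[C@H]1C(C)C`: 3.54

All three values come from a physicochemical assay for lipophilicity, measured as octanol-water partition; on this read-out higher numbers stand for higher lipophilicity and lower numbers for lower lipophilicity. Compound 1 sits in the middle of the three, with compound 3 lower and compound 2 higher, and both gaps lie beyond the usual scatter.

The next compound to be measured is compound 4 `CC(C)[C@@H]1CC[C@@H](C)C[C@H]1OC(=O)c1ccccc1Cl`. It differs from compound 1 in one place: chloro in place of methoxy on an aromatic carbon, ortho to a large group (chloro in place of methoxy on an aromatic carbon).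

Within the data shown here, no measured pair here shows this single change, so its size can only be judged. A rise beyond the scatter is expected, though probably not one that carries the number all the way to the top of the series. Compound 2, which also carries a halogen, gives 5.61, and that value serves as a rough upper guide. The expected change is a number 0.63 log units higher from compound 1 to compound 4 (beyond the scatter). For compound 4 the estimated value is 5.2, with an expected range of 4.8 to 5.6.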

Compound 4, partition coefficient: 5.34
Compound 4: the middle estimate sits 0.14 log units below what was measured; the measured number falls inside the stated range.
By their numbers in this assay, from the lowest: compound 3; then compound 1; then compounds 4 and 2 (each within the scatter of the next).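

In this assay, among these compounds, putting chloro in place of methoxy on an aromatic carbon, ortho to a large group, gives a number 0.77 log units higher from compound 1 to compound 4 (beyond the scatter), the first single change that can be read. With the rest of the structure held constant, it shows that the group at this one position can, by itself, shift the number by more than the usual scatter. No measurement shown here explains why the number moves in this direction.

This single swap does not show how other groups would behave on the same carbon, such as fluoro, methyl or a nitrile. It also leaves open whether the same swap would give a step of similar size on another carbon of the aromatic ring.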